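A few compounds are considered here, and "the series" means these few. Any claim that something is new, unique, unknown or untested is made for them only; others in the source may bear on it.

Compound 1 `Nc1nc(N/N=C/c2ccc3ncccc3c2)nc2c1ncn2[C@@H]1O[C@H](CO)[C@@H](O)[C@H]1O` gives 9.8 nM in an assay on CHO-K1 cells for displacement of a labelled ligand from adenosine receptor A1 (Homo sapiens), read by scintillation counting, with a stated time of 60 min; on this read-out higher numbers stand for weaker inhibition and lower numbers for stronger inhibition. Compound 2 `Nc1nc(N/N=C/c2cccnc2Cl)nc2c1ncn2[C@@H]1O[C@H](CO)[C@@H](O)[C@H]1O` gives 4.6 nM in this assay, and the step of a 2.1-fold lower number from compound 1 to compound 2 (0.33 log units; beyond the scatter) is modest. Compound 3 `Nc1nc(N/N=C/c2ccc(N(c3ccccc3)c3ccccc3)cc2)nc2c1ncn2[C@@H]1O[C@H](CO)[C@@H](O)[C@H]1O` reaches only the limit > 10000 nM in this assay, so it gives no number. Among the two numbers shown, compound 2 stands lowest, with compound 1 the nearest. Compound 4 `CN(C)c1ccc(/C=N/Nc2nc(N)c3ncn([C@@H]4O[C@H](CO)[C@@H](O)[C@H]4O)c3n2)cc1` differs from compound 2 by 4-(dimethylamino)phenyl in place of 2-chloropyridin-3-yl on a carbon with a double bond to nitrogen. Within the data shown here, the only measured step at the carbon with a double bond to nitrogen, a 2.1-fold lower number from compound 1 to compound 2 (0.33 log units; beyond the scatter), was modest, while compound 3, carrying its own group there, sits at the limit of > 10000 nM in this assay, at which 1 of the 3 values shown sits. A small step toward a higher number is therefore expected, a 3.3-fold higher number from compound 2 to compound 4 (0.51 log units; beyond the scatter). Compound 4 is estimated at 15 nM, within 4 nM to 60 nM.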

Compound 4, inhibition constant: > 10000 nM
Compound 4: only a limit was reported; the forecaster's own chance of this, stated with the estimate: 5%; at least 660-fold (2.82 log units) between middle value and limit.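

Replacing either 2-chloropyridin-3-yl or quinolin-6-yl with 4-(dimethylamino)phenyl on a carbon with a double bond to nitrogen has a far larger effect than the earlier modest step (an at least 2100-fold higher number from compound 2 to compound 4 (3.33 log units; beyond the scatter); an at least 1000-fold higher number from compound 1 to compound 4 (3.00 log units; beyond the scatter)). Compound 4 reached only a limit, so both steps are lower bounds. The two compounds carrying a six-membered aromatic ring of carbon only at this place, compound 3 and compound 4, both fall at the same limit: the limit of > 10000 nM in this assay, at which 2 of the 4 values shown sit.

From the compounds shown here alone, whether the loss follows the carbon-only ring or its nitrogen substituent stays open. An unsubstituted phenyl group here would separate the two.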